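Swapping a Benzyl for a 2-(Methylsulfonyl)ethyl

The source may report more compounds than this note shows. Statements on the series, on what has been measured and on what is new or still open speak of the compounds shown alone.

Of the compounds shown here, three have been tested in a functional assay on the whole organism with Rattus norvegicus as the target; on this read-out higher numbers stand for an effect only at larger amounts of compound and lower numbers for an effect already at smaller amounts. Compound 1 `CCC(C)(C)c1ccc2nc(N)sc2c1` gives only a limit of the assay, > 10 mg/kg. Compound 2 `Nc1nc2ccc(C(=O)C(F)(F)F)cc2s1` likewise gives only a limit, > 10 mg/kg. Compound 3 `N=c1sc2cc(OC(F)(F)F)ccc2n1Cc1ccccc1` also reaches only a limit, > 10 mg/kg. Compound 3 therefore stands where every measured compound stands, at the limit of > 10 mg/kg in this assay, at which 3 of the 3 values shown sit, with no number behind it.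

Compound 4 `CS(=O)(=O)CCn1c(=N)sc2cc(OC(F)(F)F)ccc21` has not yet been measured in this assay. It differs from compound 3 in one place: (methylsulfonyl)methyl in place of phenyl on a saturated chain carbon bound to an aromatic nitrogen. Cut one bond further out, the change reads benzyl to 2-(methylsulfonyl)ethyl.

Among the compounds with values here, no step between two measured compounds is known, so there is nothing to show how large a change such a swap brings on this assay. The expected step is therefore a step that the limit leaves unreadable from compound 3 to compound 4, nothing beyond the usual scatter, and most likely another limit. Compound 4 is expected to give 15 mg/kg, with a range from 4 mg/kg to 60 mg/kg.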

Compound 4, dose for half-maximal effect: 1.8 mg/kg
Compound 4: the middle estimate sits 8.3-fold (0.92 log units) above what was measured, and the stated range ends above it.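

In this assay, the group on the saturated chain carbon bound to an aromatic nitrogen clearly matters: replacing phenyl with (methylsulfonyl)methyl, which turns benzyl into 2-(methylsulfonyl)ethyl, gives an at least 5.5-fold lower number from compound 3 to compound 4 (0.74 log units; beyond the scatter). Within the data shown here, compound 4 is the first compound here with a real number, 1.8 mg/kg, so this change moves the read-out to a range that can actually be measured. The step is only a minimum, and compound 4 is the only compound shown that is not at the limit: the limit of > 10 mg/kg in this assay, at which 3 of the 4 values shown sit.

The swap removes the aromatic ring and brings in the sulfonyl group in a single move, and the compounds shown do not separate these two changes. A plain ethyl chain, a 2-methoxyethyl chain or a longer chain ending in the same methylsulfonyl group would help tell them apart.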